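Dichloro core on the ortho-substituted benzyl series

The source may hold more compounds than are shown below. What is called first, only, known or untested is meant among the compounds shown, and "the series" means these compounds.

For the measured compounds named here, compound 2 `ClCc1ccccc1Cn1cnc2ncnc(Cl)c21` gives the highest of the two numbers so far: in a functional assay on A549 cells (Homo sapiens) for cytotoxicity, read by sulforhodamine B assay, with a stated time of 48 h (a higher number here means a weaker inhibitor of growth, a lower number a stronger inhibitor of growth), compound 2 gives 4460 nM. Going by the values given here, compound 1 `ClCc1ccc(Cn2cnc3nc(Cl)nc(Cl)c32)cc1` differs from compound 2 in more than one place and so forms no single step with it; in this assay compound 1 gives 2130 nM, a number beyond the scatter below that of compound 2. Compound 3 `ClCc1ccccc1Cn1cnc2nc(Cl)nc(Cl)c21` is the next member: it is compound 2 with chloro in place of hydrogen on an aromatic carbon. Among the compounds with values here, no measured pair in this set isolates the effect of that change alone, so its size cannot be read from the data. Compound 1, carrying the same two chloro groups on its core, sits lower than compound 2, which gives a weak hint toward a lower number; the expected step is therefore small and downward, estimated as a 1.6-fold lower number from compound 2 to compound 3 (0.20 log units; within the scatter). Compound 3 is expected to give about 2800 nM in this assay, within 1200 nM to 6500 nM.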

Compound 3, concentration for 50% growth inhibition: 2810 nM
Compound 3: middle estimate off by 1.0-fold (0.00 log units), on the low side, and the stated range covers the measured number.
By their numbers in this assay, from the lowest: compounds 1, 3 and 2 (each within the scatter of the next, the first and the last beyond it).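

Swapping hydrogen for chloro on the aromatic carbon between two ring nitrogen atoms gives the first single-place comparison in this series: in this assay, the step is a 1.6-fold lower number from compound 2 to compound 3 (0.20 log units; within the scatter). Chloro at this position therefore leaves the growth-inhibition read-out within the scatter, and the two compounds cannot be separated in this assay. No measurement at hand bears on the reason for this outcome.

Going by these compounds, only hydrogen and chloro are compared at this position, so the effect of an amine or a methoxy group there remains open. Also open, on these data alone, is whether the chloromethyl group on the benzyl ring matters to the read-out, which would need a pair differing only by a methyl or hydroxymethyl group in its place.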